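Swapping a methylphenyl for a chlorophenyl on the benzyl arm

This account rests on a few compounds, and the source may have more. Where it says the series, first, only, none or still open, it means among the compounds named here.

Three compounds share one core and differ only in the group carried on a saturated chain carbon bound to an aromatic carbon. In an in vitro functional assay on cells for agonist activity at Bombesin receptor subtype-3 (Mus musculus), read by luminescence and calcium flux (on this read-out higher numbers stand for an effect only at larger amounts of compound and lower numbers for an effect already at smaller amounts), compound 1 `O=C(O)c1ccccc1-c1ccc(CCc2ncc(CC3CCCCC3)[nH]2)cc1` gives 7.3 nM, compound 2 `COc1ccc(Cc2cnc(CCc3ccc(-c4ccccc4C(=O)O)cc3)[nH]2)cc1` gives 513 nM, and compound 3 `Cc1cccc(Cc2cnc(CCc3ccc(-c4ccccc4C(=O)O)cc3)[nH]2)c1` gives 75 nM. Compound 3 stands second highest of the three numbers: it is separated from compound 1 by a 10-fold higher number from compound 1 to compound 3 (1.01 log units; beyond the scatter) and from compound 2 by a 6.8-fold lower number from compound 2 to compound 3 (0.84 log units; beyond the scatter), both beyond the scatter.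

Compound 4 `O=C(O)c1ccccc1-c1ccc(CCc2ncc(Cc3ccc(Cl)cc3)[nH]2)cc1` is the next step from compound 3: 4-chlorophenyl in place of 3-methylphenyl on a saturated chain carbon bound to an aromatic carbon. Among the compounds with values here, two measured steps bear on this change. The move from a cyclohexyl to a 4-methoxyphenyl gave a 70-fold higher number from compound 1 to compound 2 (1.85 log units; beyond the scatter), while the change from that 4-methoxyphenyl to a 3-methylphenyl gave a 6.8-fold lower number from compound 2 to compound 3 (0.84 log units; beyond the scatter). Within this small set, a group bearing its substituent in the 4-position on the phenyl ring has so far given the highest number, and the 4-chlorophenyl of compound 4 also carries its substituent there. Within the data shown here, the step from compound 3 to compound 4 is therefore expected to be a 2.0-fold higher number from compound 3 to compound 4 (0.30 log units; within the scatter) in this assay, a rise in the number rather than a fall, though smaller than the one seen for compound 2 is plausible since chlorine is not methoxy. For compound 4 the estimate in this assay is 150 nM, with a range from 40 nM to 600 nM.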

Compound 4, half-maximal effective concentration: 102 nM
For compound 4 the middle estimate is 1.5-fold (0.17 log units) above the measured one; measured number inside the range.
By their numbers in this assay, from the lowest: compound 1; then compounds 3 and 4 (each within the scatter of the next); then compound 2.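

In this assay the exchange of 3-methylphenyl for 4-chlorophenyl gives a 1.4-fold higher number from compound 3 to compound 4 (0.13 log units; within the scatter) and so does not separate these two groups on this saturated chain carbon, although they differ both in the substituent and in where the name places it on the ring. The other new comparison, a 5.0-fold lower number from compound 2 to compound 4 (0.70 log units; beyond the scatter), shows that carrying a substituent in the 4-position does not by itself give the high number of compound 2, since 4-methoxyphenyl and 4-chlorophenyl differ only in chloro against methoxy and their numbers still lie clearly apart. The last step, a 14-fold higher number from compound 1 to compound 4 (1.15 log units; beyond the scatter), adds a third aromatic group to the two already seen, and all three of compound 2, compound 3 and compound 4 stand beyond the scatter above the cyclohexyl of compound 1.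

Nothing shown here explains these differences. Still open, from the compounds shown here alone, is whether the low number of compound 1 extends to other saturated rings such as cyclopentyl or tetrahydropyranyl, and whether a 3-chlorophenyl group would match its 4-chlorophenyl isomer in compound 4.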